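The source may report more compounds than this note shows. Statements on the series, on what has been measured and on what is new or still open speak of the compounds shown alone.

Measured so far in a physicochemical assay for lipophilicity, measured as octanol-water partition, at pH 7.4; on this read-out higher numbers stand for higher lipophilicity and lower numbers for lower lipophilicity:
compound 1, `CCc1ccc(NC2=NCCC3(CCCCC3)S2)cc1`, gives 2.31
compound 2, `Fc1ccc(NC2=NCCC3(CCCCC3)S2)cc1Cl`, gives 2.03
compound 3, `CNC1=NCCC2(CCCCC2)S1`, gives 0.88

Compound 1 holds the highest of the three numbers in this assay. Compound 2 lies within the usual scatter of it, so no order between the two is claimed; compound 3 lies well below, beyond the scatter. Compound 4, `Nc1ccc(NC2=NCCC3(CCCCC3)S2)cc1`, is not yet measured. It differs from compound 1 in one place: amino in place of ethyl on an aromatic carbon, on an aromatic carbon of a six-membered aromatic ring of carbon only, para to a large group. Among the compounds with values here, no pair of measured compounds covers this change, so the expectation rests on the change itself. The expected step of a number 1.81 log units lower from compound 1 to compound 4 (beyond the scatter) is downward and beyond the scatter. Compound 4 is estimated at 0.5, with a range from -0.2 to 1.2.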

Compound 4, distribution coefficient: 1.88
Compound 4: the middle estimate sits 1.38 log units below what was measured; the whole stated range lies below it.
By their numbers in this assay, from the lowest: compound 3; then compounds 4, 2 and 1 (each within the scatter of the next, the first and the last beyond it).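

In this assay, within the data shown here, amino in place of ethyl on an aromatic carbon, para to a large group, gives a number 0.43 log units lower from compound 1 to compound 4 (beyond the scatter) and so gives the first single-place step, a modest one. At this position, then, exchanging a group with no hydrogen-bond donors or acceptors for one that has them moves the number only this far. Nothing on hand accounts for the size of this step.

From the compounds shown here alone, whether a hydroxyl, a carboxylic acid or a longer chain at the same place would give a step of similar size stays open. So does whether amino would give a similar step elsewhere on the ring.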